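The compounds below may be only part of what the source reports. "The series", "measured", "known", "first", "only" and "open" are said of these compounds alone.

The three measured compounds share a common core in which a saturated chain links two amine nitrogens held in rings. Compound 1 `O=C1C2CCCCN2C(=O)N1CCCCN1CCN(c2cccc(C(F)(F)F)c2)CC1` carries one kind of end group, and in an assay on membranes from Cerebral cortex with Alpha-1A adrenergic receptor (Rattus norvegicus) as the target, read by radioligand binding (a lower number here means a stronger inhibitor, a higher number a weaker inhibitor), compound 1 gives 72.4 nM. Compound 2 `COc1ccccc1N1CCN(CCCCN2CC3CCCN3C2)CC1` carries a fused bicyclic amine at that end, and in this assay compound 2 gives 72.6 nM. Compound 3 `Clc1cccc(N2CCN(CCCCN3CC4CCCN4C3)CC2)c1` differs from compound 2 only at the aryl end, and in this assay compound 3 gives 64.9 nM. Compound 2 thus gives the highest of the three numbers, yet both of its neighbours lie within the scatter of it, so the three cannot be told apart on these data.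

Compound 4 `COc1ccccc1N1CCN(CCCCN2CC3CCCCN3C2)CC1` has not yet been measured. It differs from compound 2 by a group of 9 heavy atoms (7 carbon, 2 nitrogen; one five-membered non-aromatic ring with 2 hetero atoms, one six-membered non-aromatic ring with 1 hetero atom) in place of a group of 8 heavy atoms (6 carbon, 2 nitrogen; one five-membered non-aromatic ring with 1 hetero atom, one five-membered non-aromatic ring with 2 hetero atoms), on a saturated chain carbon, four bonds along the chain from an amine nitrogen in a ring. For the measured compounds named here, the single step between measured compounds, a 1.1-fold lower number from compound 2 to compound 3 (0.05 log units; within the scatter), concerns the aryl end rather than the bicyclic amine, so no measured step bears directly on this ring enlargement. With nothing in the set moving beyond the scatter, the plain expectation is that the number for compound 4 stays near that of compound 2. Compound 4 is therefore expected to give 75 nM, within the range 25 nM to 220 nM. On these data alone, the expected step, a 1.0-fold higher number from compound 2 to compound 4 (0.01 log units; within the scatter), is none beyond the scatter, the range being kept wide since this part of the molecule is untested.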

Compound 4, inhibition constant: 45 nM
The estimate for compound 4 lay 1.7-fold (0.22 log units) above the measured number, within the range that was stated.
By their numbers in this assay, from the lowest: compounds 4, 3, 1 and 2 (each within the scatter of the next).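

In this assay, the only step shown at the bicyclic amine end, on a saturated chain carbon, four bonds along the chain from an amine nitrogen in a ring, is a 1.6-fold lower number from compound 2 to compound 4 (0.21 log units; within the scatter). The earlier step, a 1.1-fold lower number from compound 2 to compound 3 (0.05 log units; within the scatter), concerned the aryl end and gave no reading at this position, whereas the new pair shows that a six-membered non-aromatic ring with 1 hetero atom can stand in place of a five-membered non-aromatic ring with 1 hetero atom without the number moving beyond the scatter. No measurement at hand accounts for the size of this step or ties it to any property of the two groups.

Whether the same ring change reads alike with 3-chlorophenyl in place of 2-methoxyphenyl remains open, since the two changes appear together in none of the compounds shown. Also open, on these data alone, is how a hydroxyl group on the bicyclic amine, or a longer chain between the two amine nitrogens, would read in this assay, and whether any change at this end can move the number beyond the scatter.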